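Swapping Fluoro for Chloro on a Phenyl Ring

The source may hold more compounds than are shown below. What is called first, only, known or untested is meant among the compounds shown, and "the series" means these compounds.

Compound 1 `COc1ccc(-c2cn3ccnc3c(-c3ccc4ncn(C5CCCCC5)c4c3)n2)cc1` gives 87.2% in a functional assay on NCI/ADR-RES cells (Homo sapiens) for inhibition, read by sulforhodamine B assay, with a stated time of 48 h, tested at 10 uM (on this read-out lower numbers stand for less inhibition and higher numbers for more inhibition at the one concentration tested (going by the name of the read-out)), whereas compound 2 `Fc1ccc(-c2cn3ccnc3c(-c3ccc4ncn(C5CCCCC5)c4c3)n2)cc1` gives 0.69% in this assay. Within the data shown here, the only measured step, a number 86.5 percentage points lower from compound 1 to compound 2 (beyond the scatter), places compound 2 at the lowest of the two numbers, far under compound 1. Compound 3 `Clc1ccc(-c2cn3ccnc3c(-c3ccc4ncn(C5CCCCC5)c4c3)n2)cc1` differs from compound 2 by chloro in place of fluoro on an aromatic carbon. Among the measured compounds shown here, no measured step exchanges one halogen for another, so the one step available only shows that removing the methoxy and putting fluoro in its place wiped out the inhibition; it says nothing directly about chloro. For the measured compounds named here, with no guiding precedent, compound 3 is expected to remain near compound 2, and the step of a number 14.3 percentage points higher from compound 2 to compound 3 (beyond the scatter) is estimated to stay within the scatter. Compound 3 is therefore expected to give about 15% in this assay, plausibly between -5% and 55%.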

Compound 3, a percentage reported as inhibition, at one concentration (the size of the read-out at that concentration, not a potency): 11.1%
Compound 3: the middle estimate sits 3.9 percentage points above what was measured; low and high end bracket the measured number.
By their numbers in this assay, from the lowest: compound 2; then compound 3; then compound 1.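

Chloro in place of fluoro, at this position on the aromatic carbon para to a large group, makes only a modest difference in this assay: there is a number 10.4 percentage points higher from compound 2 to compound 3 (beyond the scatter), so this is the first direct look at one halogen exchanged for another. Set against methoxy, chloro behaves much as fluoro did, with a number 76.1 percentage points lower from compound 1 to compound 3 (beyond the scatter), so the high inhibition of compound 1 returns with neither halogen. No measurement available here accounts for the gap between methoxy and the two halogens.

Still open, going by these compounds, is whether methoxy is unusual at this position, or whether ethoxy, hydroxyl or an amine would give similarly high inhibition. It is also unknown whether bromo would extend the small rise seen on going from fluoro to chloro.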